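Amide-nitrogen swap on the shared core

The compounds below may be only part of what the source reports. "The series", "measured", "known", "first", "only" and "open" are said of these compounds alone.

Compound 1 `COc1ccc2c(=O)c(/C=C/C(=O)NCc3ccc(F)cc3)coc2c1`: in a functional assay on HeLa cells (Homo sapiens) for inhibition, read by MTT assay, with a stated time of 48 h (on this read-out higher numbers stand for weaker inhibition and lower numbers for stronger inhibition), compound 1 reads only as the assay limit > 100000 nM.
Compound 2 `O=C(/C=C/c1coc2cc(O)ccc2c1=O)NCc1ccc(F)cc1`: in this assay compound 2 likewise reads only as the assay limit > 100000 nM.

Among the compounds with values here, both measured values sit at the limit of > 100000 nM in this assay, at which 2 of the 2 values shown sit, and the one step that the two limits leave unreadable from compound 1 to compound 2 is unreadable. Compound 2 thus stands at a limit only, with no number beneath it. Compound 3 `COc1ccc(NC(=O)/C=C/c2coc3cc(O)ccc3c2=O)cc1` differs from compound 2 by 4-methoxyphenyl in place of 4-fluorobenzyl on an amide-type nitrogen. No readable measured step bears on this change, so no direction or size beyond the scatter can be set for this assay. Compound 3 is expected to give 100000 nM, within 20000 nM to 300000 nM. The step is estimated as a number no higher from compound 2 to compound 3 (the limit leaves the size open), most likely again a limit.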

Compound 3, half-maximal inhibitory concentration: > 100000 nM
Compound 3: a limit, no number; the forecaster's own chance of this, stated with the estimate: 75%; the middle value lies on the limit itself.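

In this assay compound 3 reads only as the limit > 100000 nM, and the step from compound 2 to compound 3 cannot be read. The compounds shown leave open whether any change on the amide-type nitrogen alters inhibition in this assay.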